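This account rests on a few compounds, and the source may have more. Where it says the series, first, only, none or still open, it means among the compounds named here.

Three compounds share one core that carries an isopropyl group, and they differ in the groups placed on the other ring carbons. Compound 1 `CC(C)=Cc1c(-c2ccccc2)sc(C(C)C)c1/C=C/[C@@H](O)C[C@@H](O)CC(=O)O` gives 1000 nM in an assay on microsomes for inhibition of 3-hydroxy-3-methylglutaryl-coenzyme A reductase (Rattus norvegicus); a higher number here means a weaker inhibitor, a lower number a stronger inhibitor. Compound 2 `CC(C)c1sc(-c2ccccc2)c(C2CCCC2)c1/C=C/[C@@H](O)C[C@@H](O)CC(=O)O` gives 417 nM in this assay. Compound 3 `CC(C)c1sc(-c2ccccc2)c(-c2ccc(F)cc2)c1/C=C/[C@@H](O)C[C@@H](O)CC(=O)O` gives 4.4 nM in this assay, the lowest of the three numbers: a 95-fold lower number from compound 2 to compound 3 (1.98 log units; beyond the scatter) and a 230-fold lower number from compound 1 to compound 3 (2.36 log units; beyond the scatter). Between the first two, a 2.4-fold lower number from compound 1 to compound 2 (0.38 log units; beyond the scatter).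

Compound 4 `CC(C)c1sc(C2CCCC2)c(-c2ccc(F)cc2)c1/C=C/[C@@H](O)C[C@@H](O)CC(=O)O` has not been measured. Compared with compound 3 the change is cyclopentyl in place of phenyl on an aromatic carbon, with the cyclopentyl entering next to the ring sulfur. Within the data shown here, no measured step alters this particular position. The closest guide is the swap at the other ring carbon, where a 95-fold lower number from compound 2 to compound 3 (1.98 log units; beyond the scatter) favoured the aromatic group over the cyclopentyl. Read in reverse for the present position, that step points to a loss, though a smaller one, since the position is not the same. Compound 4 is therefore expected to give 15 nM, with a likely range from 4 nM to 60 nM. The expected step is a 3.4-fold higher number from compound 3 to compound 4 (0.53 log units; beyond the scatter).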

Compound 4, half-maximal inhibitory concentration: 570 nM
For compound 4 the middle estimate is 38-fold (1.58 log units) below the measured one; measured number above the stated range.
By their numbers in this assay, from the lowest: compound 3; then compounds 2, 4 and 1 (each within the scatter of the next, the first and the last beyond it).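

On the carbon next to the ring sulfur, the phenyl of compound 3 matters a great deal in this assay: cyclopentyl in its place gives a 130-fold higher number from compound 3 to compound 4 (2.11 log units; beyond the scatter) in this series. Until now, only the neighbouring ring carbon had shown such sensitivity, with a 95-fold lower number from compound 2 to compound 3 (1.98 log units; beyond the scatter) when 4-fluorophenyl took the place of cyclopentyl there, so compound 3 now loses much of its inhibition when cyclopentyl enters at either carbon. Nothing measured here explains the size of this step.

Phenyl and cyclopentyl differ both in ring size and in being aromatic or not, so the compounds shown cannot separate these two differences. Going by these compounds, how a cyclohexyl group, a pyridine ring or a 4-fluorophenyl group would behave on this carbon remains open.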